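Cytotoxicity notes on a triazole series, toward compound 4

The source may report more compounds than this note shows. Statements on the series, on what has been measured and on what is new or still open speak of the compounds shown alone.

Compound 1 `Cn1cc(SCc2nnc(S)n2-c2c(Cl)cccc2Cl)c2ccccc21` gives > 100000 nM in a toxicity assay on HEK-293T cells (Homo sapiens) for cytotoxicity, read by CCK-8 assay, with a stated time of 48 h; on this read-out higher numbers stand for lower toxicity in this test and lower numbers for higher toxicity in this test; this value is a limit of the assay.
Compound 2 `Cn1cc(SCc2nnc(SCc3ccccc3)n2-c2c(Cl)cccc2Cl)c2ccccc21` gives > 100000 nM in this assay; this too is a limit.
Compound 3 `Cn1cc(SCc2nnc(SCc3ccccc3C#N)n2-c2c(Cl)cccc2Cl)c2ccccc21` gives 78600 nM in this assay.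

Within the data shown here, compound 3 carries the only actual number in this assay; the remaining two values sit at the limit of > 100000 nM in this assay, at which 2 of the 3 values shown sit. The change to compound 4 `Cn1cc(SCc2nnc(SCc3ccccc3OC(F)(F)F)n2-c2c(Cl)cccc2Cl)c2ccccc21` is trifluoromethoxy in place of cyano on an aromatic carbon. The steps that touch the same position are an at least 1.2-fold lower number from compound 2 to compound 3 (0.10 log units; that floor lies within the scatter) and an at least 1.2-fold lower number from compound 1 to compound 3 (0.10 log units; that floor lies within the scatter), both with floors inside the scatter, while a step that the two limits leave unreadable from compound 1 to compound 2 cannot be read. No step beyond the scatter is therefore expected in this assay in either direction; the expected step is a 1.1-fold higher number from compound 3 to compound 4 (0.06 log units; within the scatter). Compound 4 is estimated at 90000 nM, between 40000 nM and 200000 nM, with a real chance that only a limit is reported.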

Compound 4, half-maximal cytotoxic concentration: > 100000 nM
Compound 4: no number, only a limit; the forecaster's own chance of this, stated with the estimate: 50%; middle value at least 1.1-fold (0.04 log units) away from the limit.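

In this assay compound 4 reaches only a limit, so a substituent on this aromatic carbon does not by itself give a measurable number. The steps involving the limits of compound 1 and compound 2 cannot be read, and trifluoromethoxy in place of cyano gives an at least 1.2-fold higher number from compound 3 to compound 4 (0.10 log units; that floor lies within the scatter). Compound 3 remains the only compound with a number: the limit of > 100000 nM in this assay, at which 3 of the 4 values shown sit.

As far as these compounds go, whether an amine or a carboxylic acid on this aromatic carbon would give a number beyond the scatter stays open. So does any difference among compound 1, compound 2 and compound 4, which share one limit.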